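A few compounds are considered here, and "the series" means these few. Any claim that something is new, unique, unknown or untested is made for them only; others in the source may bear on it.

Working notes on the series. All three measured compounds share one core and differ only in the aryl group on the ring nitrogen of the piperazine. Compound 1 is `O=C(NCCCCN1CCN(c2ccccc2)CC1)c1ccc(-c2ccsc2)cc1`; in an ADME assay on microsomes from liver (Rattus norvegicus) for metabolic stability, read by LC-MS, using NADPH (a higher number here means that the compound lasts longer, a lower number that the compound disappears faster), compound 1 gives 0.41 h. Compound 2 is `O=C(NCCCCN1CCN(c2ccc(Cl)cc2)CC1)c1ccc(-c2ccsc2)cc1`; in this assay compound 2 gives 0.837 h, and the step of a 2.0-fold higher number from compound 1 to compound 2 (0.31 log units; beyond the scatter) is modest. Compound 3 is `COc1ccccc1N1CCN(CCCCNC(=O)c2ccc(-c3ccsc3)cc2)CC1`; in this assay compound 3 gives 0.04 h, the lowest of the three numbers, with a 10-fold lower number from compound 1 to compound 3 (1.01 log units; beyond the scatter) and a 21-fold lower number from compound 2 to compound 3 (1.32 log units; beyond the scatter) both large.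

Compound 4 is `O=C(NCCCCN1CCN(c2cccc(O)c2)CC1)c1ccc(-c2ccsc2)cc1`. Relative to compound 3 the change is 3-hydroxyphenyl in place of 2-methoxyphenyl on an amine nitrogen in a ring. Going by the values given here, two measured steps bear on it. The step of a 10-fold lower number from compound 1 to compound 3 (1.01 log units; beyond the scatter) shows what adding the methoxy group to the unsubstituted phenyl did; compound 4 removes that methoxy again, so the reverse of that step is the nearest guide and points upward, toward the level of compound 1. The step of a 21-fold lower number from compound 2 to compound 3 (1.32 log units; beyond the scatter) likewise shows a large drop whenever the 2-methoxyphenyl entered. Among the compounds with values here, no measured compound carries a hydroxyl group, so the contribution of the entering group is unknown. A rise in this assay is therefore expected for compound 4, likely large but not necessarily reaching compound 1. The number for compound 4 in this assay is expected at 0.3 h, between 0.08 h and 1 h. The expected step is a 7.5-fold higher number from compound 3 to compound 4 (0.88 log units; beyond the scatter).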

Compound 4, half-life: 0.085 h
Beside the measured number, compound 4's estimate is 3.5-fold (0.55 log units) above it; low and high end bracket the measured number.
By their numbers in this assay, from the lowest: compound 3; then compound 4; then compound 1; then compound 2.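

In this assay, taking the methoxy off compound 3 and placing a hydroxy elsewhere on the phenyl ring recovers only a modest part of the loss, a 2.1-fold higher number from compound 3 to compound 4 (0.33 log units; beyond the scatter). The low number is therefore not unique to the 2-methoxyphenyl group: the 3-hydroxyphenyl group also lies under the unsubstituted phenyl, a 4.8-fold lower number from compound 1 to compound 4 (0.68 log units; beyond the scatter), and further still under the 4-chlorophenyl group, a 9.8-fold lower number from compound 2 to compound 4 (0.99 log units; beyond the scatter). Among the four compounds, both oxygen-bearing aryl groups therefore give lower numbers than the unsubstituted phenyl, while compound 2, with its chlorine-bearing aryl group, goes against any general fall on substitution of that ring.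

No supporting measurement is available to explain these differences between the aryl groups. Compound 3 and compound 4 differ both in the oxygen-bearing group and in where it sits on the ring, so the two contributions cannot be separated, and an amine or a carboxylic acid in place of the hydroxy, or a 2-hydroxyphenyl group on the same ring nitrogen, would be needed to tell whether the group or its place sets the number.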